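From Methoxy to Ethoxy: One Added Methyl

This account rests on a few compounds, and the source may have more. Where it says the series, first, only, none or still open, it means among the compounds named here.

Measured so far in an ADME assay for permeability, using PAMPA, at pH 7.4; a lower number here means that the compound crosses the layer more slowly, a higher number that the compound crosses the layer faster:
- Compound 1 `CCOC(=O)c1c(-c2cccc(-c3ccccc3)c2)[nH]c2cc(OC)ccc2c1=O`: 2900 10^-6 cm/s
- Compound 2 `CCOC(=O)c1c(-c2cccc(OC)c2)[nH]c2cc(OC)ccc2c1=O`: 170 10^-6 cm/s

Compound 2, at 170 10^-6 cm/s, holds the lower of the two numbers. Compound 3 `CCOC(=O)c1c(-c2cccc(OCC)c2)[nH]c2cc(OC)ccc2c1=O` has not yet been measured. It differs from compound 2 by a single small edit: methyl in place of hydrogen on a saturated chain carbon bound to an oxygen on an aromatic ring. In words, this is methyl in place of hydrogen on a saturated chain carbon bound to an oxygen on an aromatic ring, so methoxy becomes ethoxy.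

Within the data shown here, only one measured step bears on this change: a 17-fold lower number from compound 1 to compound 2 (1.23 log units; beyond the scatter). That step is large, but it replaces a whole phenyl with methoxy, a much bigger edit than adding one methyl. With a single pair to go on, it offers only a weak hint of direction, towards a slightly higher number in this assay, and no firm guide to size. The expected change is small and may not exceed the scatter: a 1.5-fold higher number from compound 2 to compound 3 (0.18 log units; within the scatter). For compound 3 the estimated value is 260 10^-6 cm/s, with an expected range of 110 10^-6 cm/s to 620 10^-6 cm/s.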

Compound 3, apparent permeability: 260 10^-6 cm/s
Estimate against measurement, compound 3: no gap at the digits printed; the measured number falls inside the stated range.
By their numbers in this assay, from the lowest: compounds 2 and 3 (each within the scatter of the next); then compound 1.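

In this assay, adding one methyl to the saturated chain carbon bound to the oxygen on the aromatic ring, which turns methoxy into ethoxy, gives a 1.5-fold higher number from compound 2 to compound 3 (0.18 log units; within the scatter), so this edit leaves compound 2 and compound 3 indistinguishable in this read-out. The wide gap to compound 1 remains: with ethoxy where compound 1 carries phenyl, the step is an 11-fold lower number from compound 1 to compound 3 (1.05 log units; beyond the scatter), and the extra methyl does not bring the number close to that of compound 1, even though the earlier step with methoxy was a 17-fold lower number from compound 1 to compound 2 (1.23 log units; beyond the scatter). No measurement at hand explains either the small step or the large one.

The compounds shown leave open whether a longer chain, such as propoxy or butoxy, would stay level with compound 2 and compound 3 or move towards compound 1. They also leave open what a group of a different kind at this place, such as an amine or a carboxylic acid at the end of the chain, would do to the number.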